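A Third Methoxyphenyl Isomer Awaits Its Growth Inhibition Value

A few compounds are considered here, and "the series" means these few. Any claim that something is new, unique, unknown or untested is made for them only; others in the source may bear on it.

Within the data shown here, in a functional assay on MCF7 cells (Homo sapiens) for inhibition, read by MTT assay, with a stated time of 24 h (a higher number here means a weaker inhibitor of growth, a lower number a stronger inhibitor of growth), compound 1 `COc1ccccc1C(=O)n1c(-c2cn(C)c3ccc(Br)cc23)nc2ccccc21` gives 36200 nM and compound 2 `COc1cccc(C(=O)n2c(-c3cn(C)c4ccc(Br)cc34)nc3ccccc32)c1` gives 18200 nM, so compound 2 stands within the scatter of the only other measured compound. Compound 3 `COc1ccc(C(=O)n2c(-c3cn(C)c4ccc(Br)cc34)nc3ccccc32)cc1` has not yet been measured. It carries 4-methoxyphenyl in place of 3-methoxyphenyl on a carbonyl carbon. Among the measured compounds shown here, the one measured step bearing on this change is a 2.0-fold lower number from compound 1 to compound 2 (0.30 log units; within the scatter), so no step beyond the scatter is expected in this assay. The estimated step is a 1.1-fold higher number from compound 2 to compound 3 (0.04 log units; within the scatter). For compound 3 the estimated value is 20000 nM, with an expected range of 8000 nM to 45000 nM.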

Compound 3, concentration for 50% growth inhibition: 19200 nM
The estimate for compound 3 lay 1.0-fold (0.02 log units) above the measured number, within the range that was stated.
By their numbers in this assay, from the lowest: compounds 2, 3 and 1 (each within the scatter of the next).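

In this assay the 4-methoxyphenyl group on this carbonyl carbon gives a 1.1-fold higher number from compound 2 to compound 3 (0.02 log units; within the scatter) and also a 1.9-fold lower number from compound 1 to compound 3 (0.28 log units; within the scatter) for the change from 2-methoxyphenyl. Among these compounds, with all three methoxyphenyl isomers now read, no step among them lies beyond the scatter, so this assay does not separate them. No supporting measurement bears on this result. The compounds shown leave open whether an aminophenyl or a carboxyphenyl group in place of methoxyphenyl on this carbonyl carbon would give a step beyond the scatter.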